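Replacing the hydroxyphenyl with a morpholine amide chain

The source may hold more compounds than are shown below. What is called first, only, known or untested is meant among the compounds shown, and "the series" means these compounds.

Compound 1 `CCOC(=O)C(=O)CC(=O)/C=C/c1cn(C=C(C)C)c2ccccc12` gives > 40 uM in an assay on isolated protein for inhibition of DNA nucleotidylexotransferase (Homo sapiens), read by scintillation counting, with a stated time of 10 min; a higher number here means a weaker inhibitor, a lower number a stronger inhibitor.
Compound 2 `C=C(C)Cn1cc(/C=C/C(=O)CC(=O)C(=O)OCC)c2ccccc21` gives > 40 uM.
Compound 3 `CCOC(=O)C(=O)CC(=O)/C=C/c1cn(-c2ccc(O)cc2)c2ccccc12` gives > 40 uM.

Each of these values is a limit of this assay rather than a number, and all three sit at the limit of > 40 uM in this assay, at which 3 of the 3 values shown sit. Compound 3 thus stands only at a limit, like its two neighbours. Compound 4 `CCOC(=O)C(=O)CC(=O)/C=C/c1cn(CC(=O)N2CCOCC2)c2ccccc12` differs from compound 3 by ((morpholin-4-yl)carbonyl)methyl in place of 4-hydroxyphenyl on an aromatic nitrogen. The measured steps at this position, a step that the two limits leave unreadable from compound 1 to compound 3 and a step that the two limits leave unreadable from compound 2 to compound 3, are unreadable, as each end is a limit. No change on the aromatic nitrogen has yet given a readable number, so no direction beyond the scatter can be expected in this assay. Compound 4 is therefore estimated at 60 uM, between 20 uM and 200 uM, most likely again reported only as a limit, with an expected step that the limit leaves unreadable from compound 3 to compound 4.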

Compound 4, concentration for 50% inhibition: > 40 uM
Compound 4 ended at the assay's limit; the forecaster's own chance of this, stated with the estimate: 85%; the middle value lies beyond the limit too.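

Among these compounds, no step between compound 1, compound 2, compound 3 and compound 4 can be read, as each value is only a limit: the limit of > 40 uM in this assay, at which 4 of the 4 values shown sit. The compounds shown leave open whether any group on the aromatic nitrogen changes inhibition at all.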